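Lengthening the chain on a long-lived acid

This account rests on a few compounds, and the source may have more. Where it says the series, first, only, none or still open, it means among the compounds named here.

In an ADME assay on microsomes from liver (Mus musculus) for metabolic stability, tested at 5 uM (a higher number here means that the compound lasts longer, a lower number that the compound disappears faster), compound 2 `CCCCCCNc1ccc(C(=O)O)cc1S(N)(=O)=O` gives > 1 h, a limit of the assay and not a number. Compound 1 `CCCCCCCCNc1ccc([N+](=O)[O-])cc1S(N)(=O)=O` gives < 0.0834 h, which is also a limit. Among the measured compounds shown here, compound 2 therefore stands at the upper of the only two readings available, and neither reading is an exact half-life.

Compound 3 `CCCCCCCCNc1ccc(C(=O)O)cc1S(N)(=O)=O` differs from compound 2 by ethyl in place of hydrogen on a saturated chain carbon, six bonds along the chain from a nitrogen on an aromatic ring. For the measured compounds named here, no measured pair shows this change, so its size is a judgement. A moderate fall in this assay is expected, because compound 1 stops at < 0.0834 h. The estimated change is an at least 2.2-fold lower number from compound 2 to compound 3 (0.34 log units; beyond the scatter). For compound 3 the estimated half-life is 0.45 h, with an expected range from 0.12 h to 1 h.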

Compound 3, half-life: 0.3 h
For compound 3 the middle estimate is 1.5-fold (0.18 log units) above the measured one; measured number inside the range.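

Read in this assay, ethyl in place of hydrogen on this saturated chain carbon has a real cost, even on the acid: an at least 3.3-fold lower number from compound 2 to compound 3 (0.52 log units; beyond the scatter). With the chain held the same, carboxy in place of nitro on an aromatic carbon pulls the other way, giving an at least 3.5-fold higher number from compound 1 to compound 3 (0.55 log units; beyond the scatter), so the longer chain alone does not decide how long a compound lasts. Neither step has an exact size, because each starts from a limit of the assay and not from a number, as with compound 2: the limit of > 1 h in this assay, at which 1 of the 3 values shown sits.

As far as these compounds go, whether a chain longer than that of compound 3 would shorten the half-life further stays open. So does whether an amide or an amine in place of the carboxy group would last as long as the acid.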